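The compounds below may be only part of what the source reports. "The series", "measured", "known", "first", "only" and "open" are said of these compounds alone.

Compound 1, `Cc1cn([C@H]2C[C@H](SSC(Cl)(Cl)Cl)[C@@H](CO)O2)c(=O)[nH]c1=O`, gives 365000 nM in an assay on isolated protein for inhibition of thymidine kinase, cytosolic (Homo sapiens), in the presence of a further agent that is not named here; on this read-out lower numbers stand for stronger inhibition and higher numbers for weaker inhibition.
Compound 2, `Cc1cn([C@H]2C[C@H](SSCCO)[C@@H](CO)O2)c(=O)[nH]c1=O`, gives 405000 nM in this assay.

Of the compounds shown here, two have been measured, and both sit at weak inhibition. Compound 2 holds the larger of the two numbers, but the step of a 1.1-fold higher number from compound 1 to compound 2 (0.05 log units; within the scatter) lies within the scatter, so the two compounds cannot be told apart on these data; the exchange of trichloromethyl for 2-hydroxyethyl on the sulfur left the read-out essentially where it was.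

Compound 3, `Cc1cn([C@H]2C[C@H](SSCCN)[C@@H](CO)O2)c(=O)[nH]c1=O`, differs from compound 2 by amino in place of hydroxy on a saturated chain carbon, two bonds along the chain from a sulfur. Within the data shown here, the only measured step that bears on this change is the one from compound 1 to compound 2, which also altered the group on the outer sulfur of the disulfide and produced no shift beyond the scatter. Among the measured compounds shown here, with a single, flat step as the sole guide, no step beyond the scatter is expected in this assay either, and the estimated step is a 1.0-fold lower number from compound 2 to compound 3 (0.01 log units; within the scatter). For compound 3 the expected value in this assay is therefore 400000 nM, with a range from 150000 nM to 1000000 nM.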

Compound 3, half-maximal inhibitory concentration: 418000 nM
For compound 3 the middle estimate is 1.0-fold (0.02 log units) below the measured one; low and high end bracket the measured number.
By their numbers in this assay, from the lowest: compounds 1, 2 and 3 (each within the scatter of the next).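

In this assay, amino in place of hydroxy on a saturated chain carbon, two bonds along the chain from a sulfur, gives a 1.0-fold higher number from compound 2 to compound 3 (0.01 log units; within the scatter) and so does not separate the two groups at this place, a comparison of the chain end alone that the earlier pair could not offer. Against the trichloromethyl of compound 1, the 2-aminoethyl group gives a 1.1-fold higher number from compound 1 to compound 3 (0.06 log units; within the scatter), so trichloromethyl, 2-hydroxyethyl and 2-aminoethyl on a sulfur now all read alike and all stay at weak inhibition. No evidence is available that would explain this flat read-out.

The compounds shown leave open whether a carboxylic acid at the end of the chain, or a longer chain such as 3-aminopropyl, would move the number out of this weak range. All three compounds also share the disulfide and the core, so they cannot show what a single sulfur or an amine in place of the disulfide would do.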